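A Phenyl Group Gives Way to Hydrogen

The compounds below may be only part of what the source reports. "The series", "measured", "known", "first", "only" and "open" are said of these compounds alone.

Compound 1 `O=C(Nc1cc(C(F)(F)F)cc(C(F)(F)F)c1)c1cc(Br)c(-c2ccccc2)cc1O` at 300 nM
Compound 2 `O=C(Nc1ccc(C(F)(F)F)cc1)c1cc(Cl)ccc1O` at 740 nM

In a functional assay on KG-1 cells (Homo sapiens) for cytotoxicity, read by luminescence and CellTiter-Glo, with a stated time of 3 days (a lower number here means a stronger inhibitor, a higher number a weaker inhibitor), compound 1 holds the lower of the two numbers, and the higher number of compound 2 lies beyond the scatter. Compound 3 `O=C(Nc1cc(C(F)(F)F)cc(C(F)(F)F)c1)c1cc(Br)ccc1O` has not yet been measured. It carries hydrogen in place of phenyl on an aromatic carbon of compound 1 (hydrogen in place of phenyl on an aromatic carbon). Within the data shown here, no measured pair shows this change, so the expectation is loose. A modest weakening in this assay is expected, and the estimated move is a 1.7-fold higher number from compound 1 to compound 3 (0.22 log units; within the scatter). For compound 3 the estimated value is 500 nM, with an expected range from 170 nM to 1500 nM.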

Compound 3, half-maximal inhibitory concentration: 300 nM
Beside the measured number, compound 3's estimate is 1.7-fold (0.22 log units) above it; the measured number falls inside the stated range.
By their numbers in this assay, from the lowest: compounds 1 and 3 (each within the scatter of the next); then compound 2.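

In this assay, hydrogen in place of phenyl on this aromatic carbon, ortho to the bromo group, gives no change at the digits printed from compound 1 to compound 3 (within the scatter). The phenyl is therefore not needed at this position to hold the number in this cell assay, a point the earlier pair, which differs in more than one place, could not show. No measurement given here accounts for this result.

Open, on these data alone, is how this position responds to groups of other kinds, such as an amine, a carboxylic acid or a methoxy group. Also open, as far as these compounds go, is whether the same change would leave the number in place with chloro instead of bromo.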